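A longer chain on a compound held at the limit

The compounds below may be only part of what the source reports. "The series", "measured", "known", "first", "only" and "open" are said of these compounds alone.

Compound 1 `CCCCCC(CCO)n1cnc2c(Cl)ncnc21`: > 50000 nM
Compound 2 `C=C(CO)C(CCCCC)n1cnc2c(Cl)ncnc21`: > 50000 nM
Compound 3 `CCCCCCCCCC(CCn1cc(-c2ccccc2)nn1)n1cnc2c(Cl)ncnc21`: 13500 nM

In a functional assay on HCT-116 cells (Homo sapiens) for antiproliferative activity, read by MTT assay, with a stated time of 48 h (a lower number here means a stronger inhibitor, a higher number a weaker inhibitor), compound 2 reads > 50000 nM as a limit and not a number. Compound 1 also reads > 50000 nM as a limit. Together they make up the limit of > 50000 nM in this assay, at which 2 of the 3 values shown sit, and leave compound 3 as the only compound with a number.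

Compound 4 `C=C(CO)C(CCCCCCCCC)n1cnc2c(Cl)ncnc21` departs from compound 2 in one place: butyl in place of hydrogen on a saturated chain carbon, six bonds along the chain from an aromatic nitrogen and a double-bonded chain carbon. For the measured compounds named here, the single measured step, a step that the two limits leave unreadable from compound 1 to compound 2, concerns another group and offers no size to carry over. The nearest guide is compound 3 at 13500 nM in this assay, which has the same long chain as compound 4 but a different side group. A gain in strength is therefore expected, though it rests on that one compound. The expected step of an at least 2.5-fold lower number from compound 2 to compound 4 (0.39 log units; beyond the scatter) runs towards a stronger inhibitor, and its size is uncertain. For compound 4 the estimate is 20000 nM within an expected range of 7000 nM to 50000 nM.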

Compound 4, half-maximal inhibitory concentration: > 50000 nM
Compound 4 gave a limit, no number; the forecaster's own chance of this, stated with the estimate: 30%; middle value at least 2.5-fold (0.39 log units) away from the limit.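

In this assay compound 4 gives > 50000 nM as a limit and not a number. Compound 2 also stands at a limit, so no step can be read from compound 2 to compound 4: the limit of > 50000 nM in this assay, at which 3 of the 4 values shown sit.

From the compounds shown here alone, whether butyl in place of hydrogen changes the strength at all stays open.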